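Replacing the imidazole on the cyclopentyl ring with a methylsulfonamide

This account rests on a few compounds, and the source may have more. Where it says the series, first, only, none or still open, it means among the compounds named here.

The study concerns a series of compounds sharing the core of compound 1, `COCCNC(=O)CCNc1ncc2c(Br)nn(-c3ccc4ncccc4c3)c2n1`, measured in an assay on isolated protein for inhibition of eIF-2-alpha kinase GCN2 (Homo sapiens); on this read-out higher numbers stand for weaker inhibition and lower numbers for stronger inhibition. For compound 1 the assay reports only a limit, > 1000 nM. Compound 2, `COCCC(=O)N[C@@H]1CC[C@@H](Nc2ncc3c(Br)nn(-c4ccc5ncccc5c4)c3n2)C1`, gives 74 nM, and compound 3, `Brc1nn(-c2ccc3ncccc3c2)c2nc(N[C@@H]3CC[C@@H](c4ncc[nH]4)C3)ncc12`, gives 21 nM. Among the two numbers given, compound 3 holds the lowest, with compound 2 as its nearest neighbour. Two measured steps lead to compound 3: an at least 47-fold lower number from compound 1 to compound 3 (1.67 log units; beyond the scatter), and a 3.5-fold lower number from compound 2 to compound 3 (0.55 log units; beyond the scatter).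

Compound 4, `CNS(=O)(=O)[C@@H]1CC[C@@H](Nc2ncc3c(Br)nn(-c4ccc5ncccc5c4)c3n2)C1`, has not yet been measured. It differs from compound 3 in one place: methylsulfamoyl in place of 1H-imidazol-2-yl on a saturated ring carbon. The step from compound 2 to compound 3 bears on this change, since both replace one polar group with another on the same saturated ring carbon, and that step was modest. The step from compound 1 to compound 3 is far larger but turns on the ring as well, so it carries less weight here. Compound 4 is therefore expected to give a somewhat higher number than compound 3, without reaching the scale seen for compound 1. This expectation amounts to a 2.9-fold higher number from compound 3 to compound 4 (0.46 log units; beyond the scatter). For compound 4 the estimated value is 60 nM, with a range from 20 nM to 180 nM.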

Compound 4, half-maximal inhibitory concentration: 43 nM
The estimate for compound 4 lay 1.4-fold (0.14 log units) above the measured number; the range from low to high includes it.
By their numbers in this assay, from the lowest: compound 3; then compounds 4 and 2 (each within the scatter of the next). At a limit, above all of these: compound 1.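

In this assay, the step of a 2.0-fold higher number from compound 3 to compound 4 (0.31 log units; beyond the scatter) shows that this saturated ring carbon tolerates a group with no ring at all, with methylsulfamoyl replacing the aromatic 1H-imidazol-2-yl at a modest cost that still lies beyond the scatter. The step of a 1.7-fold lower number from compound 2 to compound 4 (0.24 log units; within the scatter) adds that methylsulfamoyl and ((2-methoxyethyl)carbonyl)amino cannot be told apart here, so two open-chain groups of different make-up give values within the scatter of each other, while only compound 3 separates from compound 2. Compound 1 is known only as a limit, so the step of an at least 23-fold lower number from compound 1 to compound 4 (1.36 log units; beyond the scatter) gives a bound and not a size, and it adds a second case, after compound 3, of a group on the five-membered ring lying well clear of that limit: the limit of > 1000 nM in this assay, at which 1 of the 4 values shown sits.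

The compounds shown leave open whether a primary amine or a carboxylic acid on the same ring carbon would hold this level, and whether a longer chain in place of the methyl would. They also leave the ring's own share unresolved, as compound 1 differs from compound 4 in ring and chain at once.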